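A few compounds are considered here, and "the series" means these few. Any claim that something is new, unique, unknown or untested is made for them only; others in the source may bear on it.

Measured compounds in a physicochemical assay for solubility, read by LC-MS, in phosphate buffer, measured as thermodynamic solubility, with a stated time of 24 h, at pH 7.4; on this read-out higher numbers stand for higher solubility and lower numbers for lower solubility:
compound 1 `Cn1cc(-c2cnc3[nH]cc(-c4ccc(C#N)cc4)c3c2)cn1` — 2000 nM
compound 2 `Cc1ccc(-c2c[nH]c3ncc(-c4cnn(C)c4)cc23)cc1` — 7000 nM
compound 3 `COc1ccc(-c2c[nH]c3ncc(-c4cnn(C)c4)cc23)cc1` — 5000 nM

Compound 2 holds the highest number of the three in this assay. Its nearest neighbour is compound 3, where the difference a 1.4-fold lower number from compound 2 to compound 3 (0.15 log units; within the scatter) is within the scatter, so the two cannot be ordered. The furthest is compound 1, with a 3.5-fold higher number from compound 1 to compound 2 (0.54 log units; beyond the scatter) and, for compound 3, a 2.5-fold higher number from compound 1 to compound 3 (0.40 log units; beyond the scatter), both modest but beyond the scatter.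

Compound 4 `Cn1cc(-c2cnc3[nH]cc(C4CCNC4)c3c2)cn1` differs from compound 2 by pyrrolidin-3-yl in place of 4-methylphenyl on an aromatic carbon. The measured steps all concern a change of one substituent on the 4-methylphenyl ring (cyano to methyl, cyano to methoxy) and leave the six-membered aromatic ring of carbon only in place; none of them removes that ring or brings in a five-membered non-aromatic ring with one hydrogen-bond donor and one hydrogen-bond acceptor. They therefore give no direct calibration of the step to compound 4, only the observation that substituent changes on that ring moved this assay by modest amounts.

The expectation for compound 4 is a step upward of an 8.6-fold higher number from compound 2 to compound 4 (0.93 log units; beyond the scatter), beyond the scatter. Compound 4 is estimated at 60000 nM, with a range from 10000 nM to 300000 nM.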

Compound 4, solubility: 1000000 nM
Estimate against measurement, compound 4: 17-fold (1.22 log units) below; the measured number lies above the stated range.
By their numbers in this assay, from the lowest: compound 1; then compounds 3 and 2 (each within the scatter of the next); then compound 4.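

At the position on an aromatic carbon of the five-membered aromatic ring, two ring bonds from the ring nitrogen, exchanging the whole group moves the number in this assay much further than the earlier substituent change on the 4-methylphenyl ring: pyrrolidin-3-yl in place of 4-methylphenyl gives a 140-fold higher number from compound 2 to compound 4 (2.15 log units; beyond the scatter) against a 3.5-fold higher number from compound 1 to compound 2 (0.54 log units; beyond the scatter) for methyl in place of cyano. This single step removes the six-membered aromatic ring of carbon only and brings in a five-membered non-aromatic ring with 1 hetero atom, 1 hydrogen-bond donor and 1 hydrogen-bond acceptor, so all of these differences travel together and the series does not separate them. No measurement at hand gives a reason for the size of this step.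

Still open, as far as these compounds go, is whether the ring nitrogen or the loss of the aromatic ring accounts for the step, a question that a cyclopentyl group at the same place would address. Also open, from the compounds shown here alone, is how far the step depends on the ring itself, as a piperidin-4-yl group or an open-chain amine there would show.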